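A few compounds are considered here, and "the series" means these few. Any claim that something is new, unique, unknown or untested is made for them only; others in the source may bear on it.

For the measured compounds named here, compound 3 `Cc1cc(Nc2nc(NCc3ccc(F)cc3)nc3[nH]ncc23)n[nH]1` gives 395 nM in an assay on isolated protein for inhibition of serine/threonine-protein kinase PAK 4 (Homo sapiens), read by HTRF, with a stated time of 60 min (on this read-out higher numbers stand for weaker inhibition and lower numbers for stronger inhibition), and stands lowest of the three numbers so far. Compound 2 `Cc1cc(Nc2nc(NCc3ccccc3Br)nc3[nH]ncc23)n[nH]1` gives 1090 nM in this assay, and compound 1 `Cc1cc(Nc2nc(Nc3ccccc3)nc3[nH]ncc23)n[nH]1` gives 5900 nM. The measured steps are a 5.4-fold lower number from compound 1 to compound 2 (0.73 log units; beyond the scatter), a 15-fold lower number from compound 1 to compound 3 (1.17 log units; beyond the scatter) and a 2.8-fold lower number from compound 2 to compound 3 (0.44 log units; beyond the scatter). Compound 4 `Cc1cc(Nc2nc(NCc3ccc(Cl)cc3)nc3[nH]ncc23)n[nH]1` differs from compound 3 by chloro in place of fluoro on an aromatic carbon. Going by the values given here, no measured step swaps one halogen for another at the same place; the only step touching the benzyl halogen, 2-bromophenyl to 4-fluorophenyl, changed both the halogen and where it sits and was modest. The new step is therefore expected to stay within the scatter or give a small drop at most. Compound 4 is expected to give 300 nM (range 120 nM to 900 nM). The expected step is a 1.3-fold lower number from compound 3 to compound 4 (0.12 log units; within the scatter).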

Compound 4, half-maximal inhibitory concentration: 515 nM
Estimate against measurement, compound 4: 1.7-fold (0.23 log units) below, and the stated range covers the measured number.
By their numbers in this assay, from the lowest: compounds 3 and 4 (each within the scatter of the next); then compound 2; then compound 1.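

Chloro in place of fluoro, para to a large group, gives no readable difference in this assay: a 1.3-fold higher number from compound 3 to compound 4 (0.12 log units; within the scatter). The 4-chlorobenzyl group also holds the gain over phenyl, an 11-fold lower number from compound 1 to compound 4 (1.06 log units; beyond the scatter), and stays ahead of 2-bromobenzyl, a 2.1-fold lower number from compound 2 to compound 4 (0.33 log units; beyond the scatter), so fluoro and chloro at this place read alike. Nothing on hand bears on the reason for these numbers.

Open, as far as these compounds go, is how a group other than a halogen, such as an amine, a methoxy group or a carboxylic acid, would read at this place. Also open, from the compounds shown here alone, is how a longer chain would read in place of the benzyl link.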